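A few compounds are considered here, and "the series" means these few. Any claim that something is new, unique, unknown or untested is made for them only; others in the source may bear on it.

Three related compounds share one core and differ only in the aryl group attached to the ethenyl chain of the amide. Compound 1 `O=C(/C=C/c1ccccc1)Nc1ccc2ncnc(Nc3cccc(Br)c3)c2c1` carries an unsubstituted phenyl there, and in a functional assay on B16-F10 cells (Mus musculus) for inhibition, read by MTT assay, with a stated time of 48 h (a lower number here means a stronger inhibitor, a higher number a weaker inhibitor), compound 1 gives 1.45 ug/mL. Compound 2 `O=C(/C=C/c1ccccc1Cl)Nc1ccc2ncnc(Nc3cccc(Br)c3)c2c1` gives 2 ug/mL, and compound 3 `O=C(/C=C/c1ccc(Br)cc1)Nc1ccc2ncnc(Nc3cccc(Br)c3)c2c1` gives 10.7 ug/mL, the highest of the three numbers, so compound 3 is the weakest inhibitor of the set. Adding a bromine to that ring produced a 7.4-fold higher number from compound 1 to compound 3 (0.87 log units; beyond the scatter), whereas the chloro analogue showed a 1.4-fold higher number from compound 1 to compound 2 (0.14 log units; within the scatter), and the two substituted rings compare as a 5.4-fold higher number from compound 2 to compound 3 (0.73 log units; beyond the scatter). Compound 4 `COc1ccc(/C=C/C(=O)Nc2ccc3ncnc(Nc4cccc(Br)c4)c3c2)cc1` differs from compound 3 by methoxy in place of bromo on an aromatic carbon. Among the compounds with values here, no measured pair sets a methoxy against a bromo, so the direction rests only on the fact that the unsubstituted ring in compound 1 gave a lower number than the brominated ring in compound 3. Taking the bromine away is therefore expected to bring the number down somewhat, a step of a 2.7-fold lower number from compound 3 to compound 4 (0.43 log units; beyond the scatter). Compound 4 is estimated at 4 ug/mL, within a range of 1.5 ug/mL to 12 ug/mL.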

Compound 4, half-maximal inhibitory concentration: 1.24 ug/mL
For compound 4 the middle estimate is 3.2-fold (0.51 log units) above the measured one, outside the stated range (below it).
By their numbers in this assay, from the lowest: compounds 4, 1 and 2 (each within the scatter of the next); then compound 3.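

Putting methoxy in place of bromo gives an 8.6-fold lower number from compound 3 to compound 4 (0.94 log units; beyond the scatter), so in this assay a group on this ring carbon does not by itself raise the number: of the two groups tried there, only bromo does. Methoxy in place of hydrogen gives a 1.2-fold lower number from compound 1 to compound 4 (0.07 log units; within the scatter), and the 4-methoxyphenyl group in place of the 2-chlorophenyl group gives a 1.6-fold lower number from compound 2 to compound 4 (0.21 log units; within the scatter), which leaves compound 3 as the only one of the four standing apart. Nothing available explains the gap between bromo and methoxy at this position.

From the compounds shown here alone, it remains open whether the high number seen with bromo also appears with a 4-chlorophenyl group, which would keep a halogen at this position. How an amine or a carboxylic acid on this ring carbon would read is open as well.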